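The source may hold more compounds than are shown below. What is called first, only, known or untested is meant among the compounds shown, and "the series" means these compounds.

Working notes on the fluorophenyl pair within this series.

Compound 1 `COc1ccc2[nH]c(-c3cccc(F)c3)cc(=O)c2c1OC` gives, in a functional assay on HCT-116 cells (Homo sapiens) for cytotoxicity, read by MTT assay, with a stated time of 48 h (on this read-out higher numbers stand for weaker inhibition and lower numbers for stronger inhibition), a value of 1200 nM. Compound 2 `COc1ccc2[nH]c(-c3ccc(F)cc3)cc(=O)c2c1OC` carries the same core with the fluorine moved; for compound 2 this assay reports only a limit, > 20000 nM. The change 4-fluorophenyl in place of 3-fluorophenyl on an aromatic carbon thus produces an at least 16-fold higher number from compound 1 to compound 2 (1.22 log units; beyond the scatter). The full extent of that step is not fixed, since compound 2 rests at the limit of > 20000 nM in this assay, at which 1 of the 3 values shown sits.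

Compound 3 `COc1cc2c(=O)cc(-c3cccc(F)c3)[nH]c2cc1O` belongs to a second core; the difference between the two cores is not broken down here. In this assay compound 3 gives 1100 nM, which sits within the scatter of the value of compound 1, so no ordering of compound 1 and compound 3 is claimed.

Compound 4 `COc1cc2c(=O)cc(-c3ccc(F)cc3)[nH]c2cc1O` is the counterpart of compound 3 within the second core, obtained by the change (4-fluorophenyl in place of 3-fluorophenyl on an aromatic carbon). The surroundings of the change are the same as for the pair compound 1 to compound 2, so the change is treated as the same one. On that basis the step from compound 3 to compound 4 is expected to resemble the earlier one, with an 18-fold higher number from compound 3 to compound 4 (1.26 log units; beyond the scatter) as the estimate of its size, resting on compound 1 moving to compound 2 by an at least 16-fold higher number from compound 1 to compound 2 (1.22 log units; beyond the scatter). Compound 4 is therefore estimated at 20000 nM, with the expected range running from 7000 nM to 60000 nM, and a real chance that the assay again returns only a limit.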

Compound 4, half-maximal inhibitory concentration: > 100000 nM
Compound 4 ended at the assay's limit; the forecaster's own chance of this, stated with the estimate: 60%; middle value at least 5.0-fold (0.69 log units) from the limit.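

In this assay, 4-fluorophenyl in place of 3-fluorophenyl gives an at least 90-fold higher number from compound 3 to compound 4 (1.95 log units; beyond the scatter), so the direction seen on the core of compound 1 also appears on the core of compound 3, and for this one change in this pair of cores the direction carries over. In this assay the entry for compound 4 is a limit of the assay, > 100000 nM, and not a number. The result does not show that the size of the step carries over from one core to the other, and the two steps can be set side by side only as follows: the same change on two cores in this assay, an at least 16-fold higher number (1.22 log units; beyond the scatter) from compound 1 to compound 2 and an at least 90-fold higher number (1.95 log units; beyond the scatter) from compound 3 to compound 4; the limit leaves it open whether they differ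

The compounds shown hold only 3-fluorophenyl and 4-fluorophenyl at this place, so it remains open whether the same step would appear with a chlorophenyl, a methoxyphenyl or an aminophenyl group there. Also open, from the compounds shown here alone, is whether a further core, for example one carrying a carboxylic acid or a longer alkoxy chain in place of a methoxy group, would show the same direction for this change.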